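This account rests on a few compounds, and the source may have more. Where it says the series, first, only, none or still open, it means among the compounds named here.

Three compounds share one core and differ only in the group on one aromatic carbon. In an ADME assay on HepG2 cells (Homo sapiens) for cytotoxicity, read by luminescence, CellTiter-Glo and ATP content, with a stated time of 72 h (on this read-out lower numbers stand for an effect already at smaller amounts and higher numbers for an effect only at larger amounts of compound), compound 1 `COc1ccccc1Oc1ccc2c(NCCCNCc3ccco3)ccnc2c1` gives 6500 nM, compound 2 `CC(C)Cc1ccc2c(NCCCNCc3ccco3)ccnc2c1` gives 16000 nM, and compound 3 `Cc1cc(C)cc(Cc2ccc3c(NCCCNCc4ccco4)ccnc3c2)c1` gives 6270 nM. Compound 3 has the lowest number of the three, yet its gap to compound 1 is within the scatter, so those two cannot be ranked. Compound 4 `COc1ccc(Oc2ccc3c(NCCCNCc4ccco4)ccnc3c2)cc1` differs from compound 3 by 4-methoxyphenoxy in place of 3,5-dimethylbenzyl on an aromatic carbon. The step of a 1.0-fold lower number from compound 1 to compound 3 (0.02 log units; within the scatter) shows that 2-methoxyphenoxy and 3,5-dimethylbenzyl gave alike numbers, while a 2.5-fold higher number from compound 1 to compound 2 (0.39 log units; beyond the scatter) and a 2.6-fold lower number from compound 2 to compound 3 (0.41 log units; beyond the scatter) set isobutyl apart. The entering group resembles that of compound 1, so compound 4 is expected to stay near that level, with the step of a 1.0-fold higher number from compound 3 to compound 4 (0.02 log units; within the scatter). Compound 4 is estimated at 6500 nM, between 3000 nM and 14000 nM.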

Compound 4, half-maximal effective concentration: 5300 nM
Estimate against measurement, compound 4: 1.2-fold (0.09 log units) above, within the range that was stated.
By their numbers in this assay, from the lowest: compounds 4, 3 and 1 (each within the scatter of the next); then compound 2.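

Placing the methoxy group as in 4-methoxyphenoxy rather than 2-methoxyphenoxy gives no readable difference at this aromatic carbon in this assay (a 1.2-fold lower number from compound 1 to compound 4 (0.09 log units; within the scatter)). 4-Methoxyphenoxy and 3,5-dimethylbenzyl also cannot be told apart (a 1.2-fold lower number from compound 3 to compound 4 (0.07 log units; within the scatter)), whereas isobutyl remains distinct from the new group (a 3.0-fold lower number from compound 2 to compound 4 (0.48 log units; beyond the scatter)). No measured evidence is available to explain these numbers.

On these data alone, it remains open how an amine or a carboxylic acid at this carbon would compare. As far as these compounds go, a longer chain in place of isobutyl is equally open.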